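Branching of the side chain on the shared core

The compounds below may be only part of what the source reports. "The series", "measured", "known", "first", "only" and "open" are said of these compounds alone.

compound 1 `CCC1([C@@H](O)C/C=C/[C@H]2[C@H](O)CC(=O)[C@@H]2C/C=C\CCCC(=O)O)CCC1` — 30 nM
compound 2 `CCCCCC1([C@@H](O)C/C=C/[C@H]2[C@H](O)CC(=O)[C@@H]2C/C=C\CCCC(=O)O)CCC1` — 20 nM

In an assay on CHO cells for binding affinity to prostaglandin E2 receptor EP2 subtype (Mus musculus) (on this read-out higher numbers stand for weaker inhibition and lower numbers for stronger inhibition), compound 2 gives 20 nM, the lowest of the two numbers; compound 1 at 30 nM lies within the scatter of it. Compound 3 `CC(C)CC1([C@@H](O)C/C=C/[C@H]2[C@H](O)CC(=O)[C@@H]2C/C=C\CCCC(=O)O)CCC1` carries isopropyl in place of butyl on a saturated chain carbon bound to a saturated ring carbon. Among the measured compounds shown here, the one measured step that touches this chain, a 1.5-fold lower number from compound 1 to compound 2 (0.18 log units; within the scatter), stayed within the scatter; no step that shortens or branches the chain has been measured. A step beyond the scatter is therefore not expected. Compound 3 is estimated at 25 nM, range 10 nM to 60 nM, meaning a 1.3-fold higher number from compound 2 to compound 3 (0.10 log units; within the scatter).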

Compound 3, inhibition constant: 40 nM
For compound 3 the middle estimate is 1.6-fold (0.20 log units) below the measured one; the range from low to high includes it.
By their numbers in this assay, from the lowest: compounds 2, 1 and 3 (each within the scatter of the next).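

Branching at this place, on a saturated chain carbon bound to a saturated ring carbon, now has a measured reading in this assay: a 2.0-fold higher number from compound 2 to compound 3 (0.30 log units; within the scatter), and a 1.3-fold higher number from compound 1 to compound 3 (0.12 log units; within the scatter). Both steps stay within the scatter, so this read-out does not separate the isobutyl chain from the two unbranched chains. No supporting evidence bears on this result.

Open, on these data alone, is whether a much longer chain, such as decyl, would also stay within the scatter. Also open, as far as these compounds go, is how a chain ending in an amine or a carboxylic acid would read here.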